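Aryl changes on the double-bonded chain: compound 4

The source may report more compounds than this note shows. Statements on the series, on what has been measured and on what is new or still open speak of the compounds shown alone.

Measured so far in an assay on isolated protein for displacement of a labelled ligand from melanin-concentrating hormone receptor 1 (Homo sapiens); on this read-out higher numbers stand for weaker inhibition and lower numbers for stronger inhibition:
compound 1 `CCCc1cc(N)c2cc(NC(=O)/C=C/c3ccc(Cl)cc3Cl)ccc2n1` gives 6.6 nM
compound 2 `CCCc1cc(N)c2cc(NC(=O)/C=C/c3ccc(F)cc3)ccc2n1` gives 130 nM
compound 3 `CCCc1cc(N)c2cc(NC(=O)/C=C/c3ccc(SC)cc3)ccc2n1` gives 9 nM

Compound 3 stands second highest of the three numbers. Its nearest neighbour is compound 1, and the step of a 1.4-fold higher number from compound 1 to compound 3 (0.13 log units; within the scatter) lies within the scatter, so the two cannot be ordered. Its furthest neighbour is compound 2, separated by a 14-fold lower number from compound 2 to compound 3 (1.16 log units; beyond the scatter), a large step. The third step, a 20-fold higher number from compound 1 to compound 2 (1.29 log units; beyond the scatter), is large as well.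

The next compound, compound 4 `CCCc1cc(N)c2cc(NC(=O)/C=C/c3ccccc3Cl)ccc2n1`, differs from compound 3 as follows: 2-chlorophenyl in place of 4-(methylsulfanyl)phenyl on a double-bonded chain carbon bound to a double-bonded chain carbon. Within the data shown here, two steps bear on this. Compound 1 carries a 2,4-dichlorophenyl, which contains a chlorine in common with the 2-chlorophenyl of compound 4, and compound 1 stands with the low numbers. Compound 2, whose ring carries only a single fluoro, is the weak member, as a 20-fold higher number from compound 1 to compound 2 (1.29 log units; beyond the scatter) shows. Among the measured compounds shown here, no measured compound carries a 2-chlorophenyl alone, so the single chlorine is untested. A number between compound 1 and compound 2 is therefore expected, and the step of a 3.3-fold higher number from compound 3 to compound 4 (0.52 log units; beyond the scatter) is expected to go upward, possibly beyond the scatter. Compound 4 is estimated at 30 nM, within a range of 8 nM to 120 nM.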

Compound 4, half-maximal inhibitory concentration: 120 nM
For compound 4 the middle estimate is 4.0-fold (0.60 log units) below the measured one; the measured number falls inside the stated range.
By their numbers in this assay, from the lowest: compounds 1 and 3 (each within the scatter of the next); then compounds 4 and 2 (each within the scatter of the next).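

In this assay, the chloro that separates compound 1 from compound 4 carries a large step (an 18-fold higher number from compound 1 to compound 4 (1.26 log units; beyond the scatter)), so the low number of the 2,4-dichlorophenyl is not held by the 2-chlorophenyl alone. On the double-bonded chain carbon, the 2-chlorophenyl and the 4-fluorophenyl cannot be ordered (a 1.1-fold lower number from compound 2 to compound 4 (0.03 log units; within the scatter)), which places compound 2 and compound 4 together as the two rings with a single halogen on the high side of the series. The 4-(methylsulfanyl)phenyl stands well apart from the 2-chlorophenyl (a 13-fold higher number from compound 3 to compound 4 (1.12 log units; beyond the scatter)), so across these four compounds a single ring substituent can reach the low group, but it does so only in compound 3, and neither single halogen does.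

A 4-chlorophenyl, a 4-methoxyphenyl or a 4-(trifluoromethyl)phenyl on the same chain carbon would show whether the low numbers follow a group named at that place on the ring or need the second chlorine of compound 1. The compounds shown offer nothing that explains any of these steps.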